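A few compounds are considered here, and "the series" means these few. Any claim that something is new, unique, unknown or untested is made for them only; others in the source may bear on it.

The measured compounds and their results:

Compound 1, `Nc1nc(Cl)c2ncn(Cc3ccc(CCl)cc3)c2n1`: 20000 nM
Compound 2, `ClCc1cccc(Cn2cnc3c(Cl)nc(Cl)nc32)c1`: 6910 nM
Compound 3, `ClCc1ccc(Cn2cnc3c(Cl)nc(Cl)nc32)cc1`: 3800 nM

All three were tested in a functional assay on HCT-15 cells (Homo sapiens) for cytotoxicity, read by sulforhodamine B assay, with a stated time of 48 h; on this read-out higher numbers stand for weaker inhibition of growth and lower numbers for stronger inhibition of growth. Compound 1 and compound 3 differ in one place only: amino in place of chloro on an aromatic carbon. This single change produced the step of a 5.3-fold higher number from compound 3 to compound 1 (0.72 log units; beyond the scatter), so the amino compound inhibits growth more weakly than its chloro counterpart. Compound 2 is built from the same atoms as compound 3, joined differently; the difference between the two cores is not broken down here. The numbers for compound 2 and compound 3 lie within the scatter of each other, so nothing can be said about which of the two is stronger, whereas compound 1 gives a higher number than compound 2 that lies beyond the scatter.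

Compound 4, `Nc1nc(Cl)c2ncn(Cc3cccc(CCl)c3)c2n1`, has not yet been measured. It stands to compound 2 as compound 1 stands to compound 3: amino in place of chloro on an aromatic carbon. The surroundings of the changed carbon read the same in both cases, so this is the same change, seen once before among these compounds. Because the earlier change gave a 5.3-fold higher number from compound 3 to compound 1 (0.72 log units; beyond the scatter), a step of similar size is expected here, and compound 4 is estimated to show a 5.1-fold higher number from compound 2 to compound 4 (0.70 log units; beyond the scatter) in this assay. Among the compounds with values here, with only one prior example to rest on, the expectation for compound 4 is 35000 nM, with a range from 15000 nM to 80000 nM.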

Compound 4, concentration for total growth inhibition: 6760 nM
Estimate against measurement, compound 4: 5.2-fold (0.71 log units) above; the whole stated range lies above it.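

In this assay, putting amino in place of chloro on an aromatic carbon of the core of compound 2 gives a 1.0-fold lower number from compound 2 to compound 4 (0.01 log units; within the scatter), so on this core the swap leaves no difference that can be told apart from the ordinary spread of repeated measurements. The same swap therefore does not carry a fixed step from one core to the other in this series, and the size of the step seen on one core could not simply be reused on the other: the same change on two cores in this assay, a 5.3-fold higher number (0.72 log units; beyond the scatter) from compound 3 to compound 1 and a 1.0-fold lower number (0.01 log units; within the scatter) from compound 2 to compound 4, 5.4-fold (0.73 log units) apart, beyond the scatter of two such steps This rests on just two matched pairs in a single cell line, so it shows that the outcome of the swap depends on the core in these pairs, but it does not show why the two cores part ways, nor which of the two results is the more typical one.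

Going by these compounds, it remains open whether a third core would follow the pair of compound 3 and compound 1 or the pair of compound 2 and compound 4. Also open, on these data alone, is how a different group on the same aromatic carbon, such as methoxy or dimethylamino, would fare on each of the two cores.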